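Compound 2 to compound 4: pyrazolyl for fluoropyridyl

This account rests on a few compounds, and the source may have more. Where it says the series, first, only, none or still open, it means among the compounds named here.

Values in a functional assay on NFS-60 cells (Mus musculus) for inhibition, with a stated time of 72 h; on this read-out lower numbers stand for stronger inhibition of growth and higher numbers for weaker inhibition of growth:
- compound 1 `Nc1ncnc2c(C(=O)Nc3cccc4c3c(Br)nn4Cc3ccccc3)csc12`: 1010 nM
- compound 2 `Nc1ncnc2c(C(=O)Nc3cccc4c3c(Br)nn4Cc3cccc(F)n3)csc12`: 233 nM
- compound 3 `Nc1ncnc2c(C(=O)Nc3cccc4c3c(Br)nn4Cc3cccc(Br)n3)csc12`: 243 nM

Compound 2 stands at the low end of the three numbers, but its nearest neighbour offers no real separation: a 1.0-fold higher number from compound 2 to compound 3 (0.02 log units; within the scatter). The other measured steps are a 4.3-fold lower number from compound 1 to compound 2 (0.64 log units; beyond the scatter) and a 4.2-fold lower number from compound 1 to compound 3 (0.62 log units; beyond the scatter).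

Compound 4 `CCn1nc(Cn2nc(Br)c3c(NC(=O)c4csc5c(N)ncnc45)cccc32)cc1C(C)C` follows from compound 2 by 1-ethyl-5-isopropyl-1H-pyrazol-3-yl in place of 6-fluoropyridin-2-yl on a saturated chain carbon bound to an aromatic nitrogen. The change falls at the same place as all three measured steps. Exchanging the halogen on the pyridine left the number unmoved, whereas replacing phenyl with either halopyridine gave a modest step. Going by the values given here, no measured compound carries a pyrazole, so these steps bear on the change only indirectly. Among the compounds with values here, they suggest a modest move towards a higher number, no larger than the step between the phenyl and fluoropyridine compounds.

The estimated step is a 2.1-fold higher number from compound 2 to compound 4 (0.33 log units; beyond the scatter).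

The estimate for compound 4 is 500 nM, with an expected range of 150 nM to 1500 nM.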

Compound 4, concentration for 50% growth inhibition: 62 nM
Compound 4: the middle estimate sits 8.1-fold (0.91 log units) above what was measured; the measured number lies below the stated range.
By their numbers in this assay, from the lowest: compound 4; then compounds 2 and 3 (each within the scatter of the next); then compound 1.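

In this assay, the place on a saturated chain carbon bound to an aromatic nitrogen is not confined to six-membered aromatic rings: the 1-ethyl-5-isopropyl-1H-pyrazol-3-yl group, a five-membered aromatic ring, gives a 3.8-fold lower number from compound 2 to compound 4 (0.57 log units; beyond the scatter) and a 3.9-fold lower number from compound 3 to compound 4 (0.59 log units; beyond the scatter). Measured against the phenyl group, the same change gives a 16-fold lower number from compound 1 to compound 4 (1.21 log units; beyond the scatter), so this place spans a wider range than the halopyridines alone had shown. Nothing available explains why the pyrazole gives the lower number.

Still open, on these data alone, is whether the step belongs to the pyrazole ring itself or to its ethyl and isopropyl groups; a pyrazole bearing methyl groups in their place would help separate these. Also open, as far as these compounds go, is how a saturated ring such as morpholine would read at this place.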